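This account rests on a few compounds, and the source may have more. Where it says the series, first, only, none or still open, it means among the compounds named here.

Compound 1 `O=C(Nc1ccc(Oc2ccnc3[nH]ccc23)cc1)c1cn(-c2ccc(Br)cc2)c2ccccc2c1=O` gives 450 nM in a functional assay on A549 cells (Homo sapiens) for inhibition, read by MTT assay, with a stated time of 72 h; a lower number here means a stronger inhibitor, a higher number a weaker inhibitor.
Compound 2 `Cn1ccc2c(Oc3ccc(NC(=O)c4cn(-c5ccc(Cl)cc5)c5ccccc5c4=O)cc3F)ccnc21` gives 250 nM in this assay.

Compound 2 has the lower of the two numbers, but compound 1 sits within the scatter of it, so neither stands apart. Compound 3 `Cn1ccc2c(Oc3ccc(NC(=O)c4cn(-c5ccc(C(F)(F)F)cc5Cl)c5ccccc5c4=O)cc3F)ccnc21` differs from compound 2 by 2-chloro-4-(trifluoromethyl)phenyl in place of 4-chlorophenyl on an aromatic nitrogen. Within the data shown here, no measured pair shows such a step, so only a modest shift in this assay, in either direction or none beyond the scatter, is expected; the estimated step is a 1.2-fold higher number from compound 2 to compound 3 (0.08 log units; within the scatter). Compound 3 is estimated at 300 nM, between 100 nM and 900 nM.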

Compound 3, half-maximal inhibitory concentration: 2050 nM
The estimate for compound 3 lay 6.8-fold (0.83 log units) below the measured number; measured number above the stated range.
By their numbers in this assay, from the lowest: compounds 2 and 1 (each within the scatter of the next); then compound 3.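

Replacing 4-chlorophenyl with 2-chloro-4-(trifluoromethyl)phenyl on the aromatic nitrogen gives an 8.2-fold higher number from compound 2 to compound 3 (0.91 log units; beyond the scatter) in this assay. This position is therefore not indifferent to its substituent, and this change weakens inhibition. Nothing shown explains why the number rises. Among these compounds, the single step changes the chlorine pattern and adds trifluoromethyl together, so it leaves open which part carries the loss. Going by these compounds, how an amine or a methoxy group on that phenyl ring would read in this assay also remains open.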